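Two measured compounds and an expected value for a third

The source may hold more compounds than are shown below. What is called first, only, known or untested is meant among the compounds shown, and "the series" means these compounds.

Compound 1 `C=CCC(N)(CO)CCc1ccc(OCCCCCCC)cc1`: 3.1 mg/kg
Compound 2 `CCCCCCCOc1ccc(CCC(N)(CO)CCC)cc1`: 7.3 mg/kg

In a functional assay on the whole organism (spleen, spleen) with Rattus norvegicus as the target (on this read-out lower numbers stand for an effect already at smaller amounts and higher numbers for an effect only at larger amounts of compound), compound 1 gives 3.1 mg/kg, the lowest of the two numbers available, while compound 2 gives 7.3 mg/kg. For the measured compounds named here, the only step measured so far, a 2.4-fold higher number from compound 1 to compound 2 (0.37 log units; beyond the scatter), is modest and lies beyond the scatter.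

Compound 3 `CCCCCCCOc1ccc(CC[C@@](N)(CO)CCO)cc1` is not yet measured. It differs from compound 1 as follows: a group of 7 heavy atoms (4 carbon, 1 nitrogen, 2 oxygen; no ring) in place of a group of 7 heavy atoms (5 carbon, 1 nitrogen, 1 oxygen; no ring), on a saturated chain carbon, two bonds along the chain from an aromatic carbon. The step from compound 1 to compound 2 bears on this change only loosely, since it also alters the group carried by the same part of the chain, and there it raised the number modestly. With a single step to lean on, the direction for compound 3 is uncertain, and a modest rise or no change beyond the scatter is expected.

Compound 3 is therefore estimated at 5 mg/kg, within 2 mg/kg to 13 mg/kg, which means an expected step of a 1.6-fold higher number from compound 1 to compound 3 (0.21 log units; within the scatter).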

Compound 3, dose for 50% inhibition: 0.018 mg/kg
Compound 3: middle estimate off by 280-fold (2.44 log units), on the high side; the measured number lies below the stated range.
By their numbers in this assay, from the lowest: compound 3; then compound 1; then compound 2.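

In this assay, this place on a saturated chain carbon, two bonds along the chain from an aromatic carbon, turns out to be far more sensitive than a 2.4-fold higher number from compound 1 to compound 2 (0.37 log units; beyond the scatter) had shown, since the new change gives a 170-fold lower number from compound 1 to compound 3 (2.24 log units; beyond the scatter) and a 410-fold lower number from compound 2 to compound 3 (2.61 log units; beyond the scatter), both large and both in the same direction. The entering group has 2 oxygen atoms where the group it replaces has 1, and it alone brings 1 defined stereocentre. No measurement shown here accounts for the size of this change.

The compounds shown do not separate the effect of the added oxygen from that of the defined stereocentre, and they do not include the opposite stereo form. They also leave open how a longer chain, an amine or a carboxylic acid would fare at this place.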